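Benzoyl for fluorophenyl on the piperazine of compound 2

This account rests on a few compounds, and the source may have more. Where it says the series, first, only, none or still open, it means among the compounds named here.

Compound 1 `N=C(N)c1cccc(C(=O)NC(C(=O)NCC2CCC(CN)CC2)c2cccc3ccccc23)c1`: 2100 nM
Compound 2 `N=C(N)c1cccc(C(=O)N[C@@H](C(=O)N2CCN(c3ccc(F)cc3)CC2)c2ccccc2)c1`: 1260 nM
Compound 3 `CSCC[C@H](NC(=O)c1cccc(C(=N)N)c1)C(=O)NCC1CCC(CN)CC1`: 7900 nM

Three compounds share a benzamidine-bearing amide core and were measured in an assay on isolated protein for binding affinity to serine protease 1 (Homo sapiens); a lower number here means a stronger inhibitor, a higher number a weaker inhibitor. In this assay compound 2 gives 1260 nM, the lowest of the three numbers. Compound 1 gives 2100 nM, which lies within the usual scatter of the value of compound 2, so the two cannot be told apart. Compound 3 gives 7900 nM, a gap from compound 2 that is beyond the scatter.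

Compound 4 `N=C(N)c1cccc(C(=O)N[C@@H](C(=O)N2CCN(C(=O)c3ccccc3)CC2)c2ccccc2)c1` has not been measured. It differs from compound 2 in one place: benzoyl in place of 4-fluorophenyl on an amine nitrogen in a ring. Among the compounds with values here, no step between two measured compounds describes such a change, so the expectation rests only on compound 2 and the change itself. The step from compound 2 to compound 4 is expected to be small in this assay, leaning toward a somewhat higher number, and is written as a 1.6-fold higher number from compound 2 to compound 4 (0.20 log units; within the scatter). Compound 4 is therefore estimated at 2000 nM, with a range from 700 nM to 6000 nM.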

Compound 4, inhibition constant: 460 nM
Compound 4: middle estimate off by 4.3-fold (0.64 log units), on the high side; the measured number lies below the stated range.
By their numbers in this assay, from the lowest: compound 4; then compounds 2 and 1 (each within the scatter of the next); then compound 3.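

Benzoyl in place of 4-fluorophenyl on the amine nitrogen in the ring gives a 2.7-fold lower number from compound 2 to compound 4 (0.44 log units; beyond the scatter) in this assay, the first single change that can be read in this set, and it shows that the number responds to the group at this position. Both groups carry one six-membered aromatic ring of carbon only, so the step comes with a change that keeps that ring while the fluorine leaves and a carbonyl, with its one hydrogen-bond acceptor, enters. Nothing measured here accounts for the lower number.

The compounds shown leave open whether the carbonyl or the loss of fluorine matters more, which an acetyl group or a 4-fluorobenzoyl group on the same nitrogen would separate. They also leave open whether groups larger than benzoyl, such as a phenylacetyl group, would extend the step.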